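The compounds below may be only part of what the source reports. "The series", "measured", "known", "first", "only" and "open" are said of these compounds alone.

In a functional assay (trachea) with Cavia porcellus as the target (a lower number here means that less compound is needed, a higher number that more compound is needed for the effect), compound 1 (`CCCn1c(=O)n(CCOCC)c(=O)c2[nH]cnc21`) gives 70 nM, and compound 2 (`CCCn1cnc2c1c(=O)n(C)c(=O)n2CCC`) gives 5000 nM. Among the compounds with values here, compound 2 therefore has the higher of the two numbers so far, and the gap to compound 1 lies beyond the scatter. Within the data shown here, these two compounds differ in more than one place, and no measured pair isolates a single change.

The next compound is compound 3 (`CCCn1c(=O)n(C)c(=O)c2c1ncn2CCC#N`), which has cyano in place of methyl on a saturated chain carbon, two bonds along the chain from an aromatic nitrogen. The same difference reads as propyl to 2-cyanoethyl. Among the measured compounds shown here, with no measured precedent for this change, no step beyond the scatter is expected in this assay, though a shift in either direction remains open. The estimated step is a 1.3-fold lower number from compound 2 to compound 3 (0.10 log units; within the scatter). The expected value for compound 3 is 4000 nM, within an estimated range of 1000 nM to 15000 nM.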

Compound 3, half-maximal effective concentration: 27600 nM
Estimate against measurement, compound 3: 6.9-fold (0.84 log units) below; measured number outside the range, above it.
By their numbers in this assay, from the lowest: compound 1; then compound 2; then compound 3.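

In this assay, within the data shown here, the change from propyl to 2-cyanoethyl, on a saturated chain carbon two bonds along the chain from an aromatic nitrogen, gives a 5.5-fold higher number from compound 2 to compound 3 (0.74 log units; beyond the scatter) and is the only single change so far that can be read. The end of this chain is therefore not indifferent: with the rest of compound 2 held fixed, putting cyano in place of methyl means that more compound is needed for the effect. Nothing at hand says what lies behind this step.

Going by these compounds, this reading rests on one pair, so it remains open whether the step belongs to the nitrile itself or would also appear with another group at the same place, such as a hydroxyl, an amine or a carboxylic acid. A longer plain alkyl chain at this place would show whether the length of the chain matters apart from the cyano group.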